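The source may hold more compounds than are shown below. What is called first, only, known or untested is meant among the compounds shown, and "the series" means these compounds.

The series here rests on a shared core carrying an amide-linked aryl group. Compound 1 `COc1ccc(-c2ccc(Cl)cc2)c2cc(C(=O)Nc3ccc(Cn4ccnc4)cc3)oc12` and compound 2 `COc1ccc(-c2ccccc2)c2cc(C(=O)Nc3ccc(F)cc3)oc12` belong to it, as does compound 3 `COc1ccc(-c2ccc(OC)c3oc(C(=O)Nc4ccc(Cn5ccnc5)cc4)cc23)cc1`, which differs in where its methoxy-bearing ring sits. All three were studied in a functional assay on the whole organism for inhibition, with Mus musculus as the target, at a dose of 10 mg/kg by the oral route (on this read-out lower numbers stand for less inhibition and higher numbers for more inhibition at the one dose given (going by the name of the read-out)), which reports how much the compound holds back the response in the live animal after a single oral dose.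

Compound 2 stands without a number: in this assay compound 2 gives "not determined" (no result reported). The same holds for compound 1, which in this assay gives "not determined" (no result reported). Only compound 3 carries a figure, giving 54% in this assay. Among the measured compounds shown here, no step between two measured compounds is therefore available to show how a change at the amide-type nitrogen shifts the read-out.

Compound 4 `COc1ccc(-c2ccccc2)c2cc(C(=O)Nc3c(Cl)cncc3Cl)oc12` is the unmeasured partner of compound 2. The change between them is 3,5-dichloropyridin-4-yl in place of 4-fluorophenyl on an amide-type nitrogen. For the measured compounds named here, with no step recorded, the size and direction of the shift can only be guessed, and the guess leans on the one measured neighbour, compound 3.

Compound 4 is expected to give about 40% in this assay, with a plausible range from 10% to 75%, an expectation that could move either way once tested.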

Compound 4, a percentage reported as inhibition, in the whole organism at one dose (the size of the read-out at that dose, not a potency): 74%
Compound 4: the middle estimate sits 34 percentage points below what was measured; low and high end bracket the measured number.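

Among the compounds shown here, compound 4 gives 74% in this assay, but compound 2 has no single number there, so no step between compound 2 and compound 4 can be read. The compounds shown leave open how 3,5-dichloropyridin-4-yl in place of 4-fluorophenyl shifts this read-out. No supporting evidence bears on the result for compound 4.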